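Pyrazoline series: phenyl versus hydrogen on the ring nitrogen

This account rests on a few compounds, and the source may have more. Where it says the series, first, only, none or still open, it means among the compounds named here.

Compound 1 `COc1ccc(OC)c(C2CC(c3ccccn3)=NN2c2ccccc2)c1` gives 27% in a functional assay on the whole organism (strain Charles Foster albino) for inhibition, with Rattus norvegicus as the target, read by paw edema, with stated times of 30 min and 3 h, at a dose of 50 mg/kg by the oral route; a higher number here means more inhibition at the dose given (going by the name of the read-out), a lower number less inhibition. Compound 2 `COc1ccc(OC)c(C2CC(c3ccccn3)=NN2)c1` differs from compound 1 by hydrogen in place of phenyl on an amine nitrogen in a ring. In this assay compound 2 gives 15%; the step is a number 12 percentage points lower from compound 1 to compound 2 (beyond the scatter). Compound 3 `CN(C)c1ccc(C2CC(c3cccnc3)=NN2c2ccccc2)cc1` gives 34% in this assay, the highest of the three numbers; against compound 1 the gap lies within the scatter, against compound 2 beyond it. The difference between the core of compound 3 and the core of compound 1 is not broken down here.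

Compound 4 `CN(C)c1ccc(C2CC(c3cccnc3)=NN2)cc1` has not been measured in this assay. It differs from compound 3 by hydrogen in place of phenyl on an amine nitrogen in a ring. Among the compounds with values here, this is the same kind of change as the one from compound 1 to compound 2, but not the same: in compound 3 the place is two ring bonds from the ring atom that bears a pyridin-3-yl group and next to the ring atom that bears a group of 9 heavy atoms, whereas in compound 1 it is two ring bonds from the ring atom that bears a pyridin-2-yl group and next to the ring atom that bears a large group. The expected step is a number 12 percentage points lower from compound 3 to compound 4 (beyond the scatter), resting on the step of a number 12 percentage points lower from compound 1 to compound 2 (beyond the scatter). Compound 4 is therefore estimated at 22% in this assay, expected between 10% and 33%.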

Compound 4, a percentage reported as inhibition, in the whole organism at one dose (the size of the read-out at that dose, not a potency): 22%
Estimate against measurement, compound 4: no gap at the digits printed; low and high end bracket the measured number.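

In this assay, hydrogen in place of phenyl on the amine nitrogen in the ring gives a number 12 percentage points lower from compound 3 to compound 4 (beyond the scatter), so the change carries from one core to the other in direction and in size: the same change on two cores in this assay, a number 12 percentage points lower (beyond the scatter) from compound 1 to compound 2 and a number 12 percentage points lower (beyond the scatter) from compound 3 to compound 4, 0 percentage points apart, within the scatter of two such steps

This agreement rests on two pairs of compounds, and it holds only for the two cores shown, one bearing pyridin-2-yl and the other pyridin-3-yl, each with its own second group on the ring. It does not show that the step would keep its size on any further core, nor does it separate the contribution of either difference between the two cores, and it gives no reason for the step.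

The compounds shown carry only phenyl or hydrogen at this nitrogen, so it remains open how a methyl, an acetyl or a benzyl group would read there. Also open, going by these compounds, is whether a substituent on that phenyl ring, such as a chlorine or a carboxylic acid, would move the number further.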